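Series notes: nitro replaced by bromo at compound 3

This account rests on a few compounds, and the source may have more. Where it says the series, first, only, none or still open, it means among the compounds named here.

Measured compounds:
compound 1 `COc1cc2c(c(OC)c1)OCN(c1ccc3oc(-c4ccccc4)cc(=O)c3c1)C2` — 79%
compound 2 `O=c1cc(-c2ccccc2)oc2ccc(N3COc4c(cccc4[N+](=O)[O-])C3)cc12` — 61.9%

In a functional assay on MCF7 cells (Homo sapiens) for inhibition, read by MTT assay, with a stated time of 48 h, tested at 30 ug/mL (a lower number here means less inhibition of growth, a higher number more inhibition of growth at the concentration tested), compound 1 gives 79%. In this assay compound 2 gives 61.9%, the lower of the two numbers; the gap to compound 1 lies beyond the usual scatter of this read-out. Within the data shown here, the two measured compounds differ in more than one place, so no single-change step can be read from them, and nothing measured so far tests the change that leads to compound 3.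

Compound 3 `O=c1cc(-c2ccccc2)oc2ccc(N3COc4c(Br)cccc4C3)cc12` is derived from compound 2 by a single change: bromo in place of nitro on an aromatic carbon. Without any measured precedent for this exchange on the shared core, the expected step in this assay is one that stays within the scatter, with no clear direction; the expected step of a number 2.1 percentage points higher from compound 2 to compound 3 (within the scatter) reflects this. The estimate for compound 3 in this assay is therefore 64%, with an expected range from 45% to 83%, the width of that range marking how little the two measured compounds constrain the outcome.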

Compound 3, percent growth inhibition at one concentration: 71.6%
The estimate for compound 3 lay 7.6 percentage points below the measured number; measured number inside the range.
By their numbers in this assay, from the lowest: compounds 2, 3 and 1 (each within the scatter of the next, the first and the last beyond it).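

Working from the nitro group of compound 2 to the bromo group of compound 3, on the aromatic carbon ortho to a fused ring and meta to a fused ring, this assay gives a number 9.7 percentage points higher from compound 2 to compound 3 (within the scatter). Among these compounds, this is the first single-change reading at this position, and it shows that growth inhibition at the tested concentration stays within the scatter when nitro, with its 2 hydrogen-bond acceptors and a double bond outside aromatic rings, gives way to bromo, with 0 hydrogen-bond acceptors. No measured property of either group is at hand to account for this reading.

Compound 1 differs from compound 2 and compound 3 in more than one place, so steps involving it cannot be read, and the contribution of its two methoxy groups remains unseparated from the rest of its structure. Also open, as far as these compounds go, is whether this position keeps the same reading with an amine or a carboxylic acid in place of bromo, or with only hydrogen on that aromatic carbon, since one nitro-to-bromo exchange fixes no trend.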